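A few compounds are considered here, and "the series" means these few. Any claim that something is new, unique, unknown or untested is made for them only; others in the source may bear on it.

Measured in a functional assay on HL-60 cells (Homo sapiens) for cytotoxicity, read by MTT assay, with a stated time of 46 h; on this read-out lower numbers stand for stronger inhibition and higher numbers for weaker inhibition:

Compound 1 `O=C1/C(=C/c2ccncc2)C(c2ccccc2)Oc2ccccc21` gives 900 nM
Compound 2 `O=C1/C(=C/c2ccccc2)C(c2ccccc2)Oc2ccccc21` gives 33300 nM
Compound 3 `Cc1ccc(/C=C2\C(=O)c3ccccc3OC2c2ccccc2)cc1` gives 40800 nM

The value of compound 3 lies within the scatter of the value of compound 2, and both numbers lie far above that of compound 1. Compound 4 `Cc1ccc(/C=C2/C(=O)c3ccccc3OC2c2ccccc2)cc1` is the next to consider. It differs from compound 3 only in geometry: the two compounds have the same atoms and bonds; at least one stereo element is drawn with a configuration in one of them and without one in the other: 1 of 2 stereo elements differ; a double bond is drawn Z in compound 3 and E in compound 4. Nothing enters or leaves.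

Going by the values given here, the one measured step, a 37-fold higher number from compound 1 to compound 2 (1.57 log units; beyond the scatter), is large, but it puts phenyl in place of pyridin-4-yl and leaves the question of double bond geometry open. Among the compounds with values here, no measured pair isolates that change, so the size of the step from Z to E is unknown. As far as these compounds go, with no evidence for a shift, no step beyond the scatter is expected in this assay, and the direction stays open. The expected change is a 1.4-fold lower number from compound 3 to compound 4 (0.13 log units; within the scatter). For compound 4 the estimated value is 30000 nM, with an expected range from 9000 nM to 90000 nM.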

Compound 4, half-maximal inhibitory concentration: 40900 nM
Compound 4: middle estimate off by 1.4-fold (0.13 log units), on the low side, within the range that was stated.
By their numbers in this assay, from the lowest: compound 1; then compounds 2, 3 and 4 (each within the scatter of the next).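

In this assay, a 1.0-fold higher number from compound 3 to compound 4 (0.00 log units; within the scatter) shows that redrawing the double bond from Z to E leaves the number within the scatter, but this says little about geometry as such because of what the two structures define: the fact that one of compounds 3 and 4 is drawn with a defined configuration and the other without, at the place where they differ A methyl on the aromatic carbon also stays within the scatter, with a 1.2-fold higher number from compound 2 to compound 4 (0.09 log units; within the scatter). With a 45-fold higher number from compound 1 to compound 4 (1.66 log units; beyond the scatter), 4-methylphenyl joins phenyl far from pyridin-4-yl on the double-bonded chain carbon, so compound 1 stays apart from compounds 2, 3 and 4.

As far as these compounds go, it remains open whether double bond geometry matters when pyridin-4-yl occupies that carbon. Also open, from the compounds shown here alone, is whether pyridin-3-yl or 4-aminophenyl there would give a number close to that of compound 1 or close to those of compounds 2, 3 and 4.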